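A few compounds are considered here, and "the series" means these few. Any claim that something is new, unique, unknown or untested is made for them only; others in the source may bear on it.

Values measured in a functional assay on MOLT-4 cells (Homo sapiens) for inhibition, read by MTT assay, with a stated time of 48 h (on this read-out higher numbers stand for weaker inhibition and lower numbers for stronger inhibition), are as follows:
- compound 1 `CCOC(=O)C(=O)CC(=O)/C=C/c1cn(-c2ccc(Cl)cc2)c2ccccc12` has "not determined" (no result reported) as its entry
- compound 2 `CC(C)CCn1cc(/C=C/C(=O)CC(=O)C(=O)O)c2ccccc21` has 20000 nM as its entry
- compound 3 `C=C(C)Cn1cc(/C=C/C(=O)CC(=O)C(=O)O)c2ccccc21` has 40000 nM as its entry

Going by the values given here, compound 3 can be compared with only one other number. Among the compounds with values here, the single measured step is a 2.0-fold higher number from compound 2 to compound 3 (0.30 log units; within the scatter) and it leaves the two compounds level, while compound 1 offers no number to compare.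

The next compound, compound 4 `O=C(/C=C/c1cn(-c2ccc(Cl)cc2)c2ccccc12)CC(=O)C(=O)O`, differs from compound 3 in one place: 4-chlorophenyl in place of 2-methylprop-2-en-1-yl on an aromatic nitrogen is the whole change, with 4-chlorophenyl in place of 2-methylprop-2-en-1-yl on an aromatic nitrogen. Compound 1 also carries 4-chlorophenyl, but it gives no number to learn from. Within the data shown here, the only guide is therefore the step within the scatter, a 2.0-fold higher number from compound 2 to compound 3 (0.30 log units; within the scatter) and it involved no aromatic ring, so it is a weak guide to this larger swap.

No change beyond the scatter is expected in this assay and the estimated move is a 1.6-fold lower number from compound 3 to compound 4 (0.20 log units; within the scatter) with much uncertainty. The expected value for compound 4 is 25000 nM within an estimated range of 8000 nM to 70000 nM overall.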

Compound 4, half-maximal inhibitory concentration: 27000 nM
For compound 4 the middle estimate is 1.1-fold (0.03 log units) below the measured one, within the range that was stated.
By their numbers in this assay, from the lowest: compounds 2, 4 and 3 (each within the scatter of the next).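

In this assay, a much larger group on the aromatic nitrogen, now with a six-membered aromatic ring, leaves the number level: putting 4-chlorophenyl in place of 2-methylprop-2-en-1-yl gives a 1.5-fold lower number from compound 3 to compound 4 (0.17 log units; within the scatter), and putting it in place of isopentyl gives a 1.4-fold higher number from compound 2 to compound 4 (0.13 log units; within the scatter). Both steps lie within the scatter, so the three compounds with numbers cannot be told apart, even though this position has now carried both open chains and an aromatic ring. Nothing measured here offers an explanation for this level result.

Steps involving compound 1 cannot be read, so the effect of its ethyl ester remains unknown. Going by these compounds, it also remains open whether an unsubstituted phenyl, a chain ending in an amine or a longer chain on this nitrogen would move the number beyond the scatter.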